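The source may report more compounds than this note shows. Statements on the series, on what has been measured and on what is new or still open speak of the compounds shown alone.

Working notes on the series. The shared core of compound 1 `COc1ccc(-c2cnccn2)c2cc(C(=O)Nc3ccncc3)oc12` carries an aryl group on the carbon-only six-membered ring and an amide to a pyridine. Compound 2 `COc1ccc(-c2cnccn2)c2cc(C(=O)Nc3ccc(Cn4ccnc4)cc3)oc12` keeps the pyrazin-2-yl group of compound 1 but carries the amide on a phenyl bearing an imidazolylmethyl group. Compound 3 `COc1ccc(-c2cccnc2)c2cc(C(=O)Nc3ccncc3)oc12` pairs the pyridin-3-yl group with the same amide as compound 1.

In a functional assay on the whole organism for inhibition, with Mus musculus as the target, at a dose of 10 mg/kg by the oral route (on this read-out higher numbers stand for more inhibition at the one dose given (going by the name of the read-out) and lower numbers for less inhibition), compound 1 is recorded as "not determined" (no result reported), and in this assay compound 2 is likewise recorded as "not determined" (no result reported): no number stands for compound 2, and one further entry of the series is also without a number. In this assay compound 3 gives 38%, the only figure available.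

Compound 4 `COc1ccc(-c2cccnc2)c2cc(C(=O)Nc3ccc(Cn4ccnc4)cc3)oc12` is the next compound to be measured in this assay. It differs from compound 2 in one place (pyridin-3-yl in place of pyrazin-2-yl on an aromatic carbon). Among the compounds with values here, no step between measured compounds exists for this change, so nothing from the series itself tells its size or direction in this assay. Within the data shown here, with compound 2 carrying no number, the only anchor is compound 3, which shares the pyridin-3-yl group and gives 38%; the amide part of compound 4 has no measured counterpart, so the expectation stays wide. Compound 4 is expected to give about 38% in this assay, estimated within 10% to 65%.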

Compound 4, a percentage reported as inhibition, in the whole organism at one dose (the size of the read-out at that dose, not a potency): 60%
The estimate for compound 4 lay 22 percentage points below the measured number, within the range that was stated.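

No step can be read between compound 2 and compound 4 in this assay: compound 2 carries no single number there. The compounds shown leave open how the exchange of pyrazin-2-yl for pyridin-3-yl changes inhibition in this assay. No supporting evidence is at hand that bears on the result for compound 4.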